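From methyl to fluoro on the aromatic carbon

This account rests on a few compounds, and the source may have more. Where it says the series, first, only, none or still open, it means among the compounds named here.

In a functional assay on HepG2 cells (Homo sapiens) for cytotoxicity, read by MTT assay, with a stated time of 72 h (on this read-out lower numbers stand for stronger inhibition and higher numbers for weaker inhibition), compound 1 (`O=C1C=CCC/C1=C\C=C\c1ccccc1`) gives 7100 nM as its half-maximal inhibitory concentration. Compound 2 (`O=C1C=CCC/C1=C\C(Br)=C\c1ccccc1`) is recorded at > 10000 nM and this is a limit of the assay, not a number. Compound 3 (`Cc1ccc(/C=C/C=C2\CCC=CC2=O)cc1`) gives 8600 nM in this assay and its nearest neighbour is compound 1, the two values lying within the scatter of each other. Compound 4 (`O=C1C=CCC/C1=C\C=C\c1ccc(F)cc1`) follows from compound 3 by fluoro in place of methyl on an aromatic carbon of a six-membered aromatic ring of carbon only, para to a large group (fluoro in place of methyl on an aromatic carbon). The step bearing most directly on this change is a 1.2-fold higher number from compound 1 to compound 3 (0.08 log units; within the scatter) for methyl in place of hydrogen on an aromatic carbon. The step of an at least 1.4-fold higher number from compound 1 to compound 2 (0.14 log units; that floor lies within the scatter) for bromo in place of hydrogen bears less on it. That change lies on a chain carbon, and its size is only a floor. Neither step is shown beyond the scatter, so no step beyond the scatter is expected in this assay here. The estimate amounts to a 1.1-fold lower number from compound 3 to compound 4 (0.06 log units; within the scatter) and this expected step stays within the scatter. The estimated value for compound 4 is 7500 nM with an expected range from 4000 nM to 12000 nM on this read-out.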

Compound 4, half-maximal inhibitory concentration: 2900 nM
Compound 4: middle estimate off by 2.6-fold (0.41 log units), on the high side; measured number below the stated range.
By their numbers in this assay, from the lowest: compound 4; then compounds 1 and 3 (each within the scatter of the next). At a limit, above all of these: compound 2.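

The aromatic carbon para to a large group proves sensitive to what it carries: in this assay fluoro in place of methyl gives a 3.0-fold lower number from compound 3 to compound 4 (0.47 log units; beyond the scatter) and fluoro in place of hydrogen gives a 2.4-fold lower number from compound 1 to compound 4 (0.39 log units; beyond the scatter) and so both steps to fluoro stand beyond the scatter, though only modestly. The earlier change on this carbon, methyl in place of hydrogen, gave only a 1.2-fold higher number from compound 1 to compound 3 (0.08 log units; within the scatter) and so had shown no response here; compound 4 is the first compound to separate from the others on this read-out, while compounds 1 and 3 remain within the scatter of each other. Nothing measured here accounts for the lower number that comes with fluoro.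

Going by these compounds, whether this step belongs to fluoro alone stays open, since chloro, methoxy or an amine on the same aromatic carbon could give a similar number or a quite different one. On these data alone, it is also open whether fluoro would lower the number with bromo on the chain carbon, as in compound 2, whose > 10000 nM is a limit of the assay and not a number.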